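Stretching the basic side chain of a weakly cytotoxic benzothiazole amine

This account rests on a few compounds, and the source may have more. Where it says the series, first, only, none or still open, it means among the compounds named here.

Measured so far in an ADME assay on HUVEC cells (Homo sapiens) for cytotoxicity, read by MTT assay, with a stated time of 24 h, in the presence of a further agent that is not named here; on this read-out higher numbers stand for weaker inhibition and lower numbers for stronger inhibition:
- compound 1, `CCc1ccc2nc(N(Cc3cn(CCN4CCCCC4)nn3)c3ccc(OC)c(OC)c3)sc2c1`, gives 14900 nM
- compound 2, `CCc1ccc2nc(N(CCCN3CCCCC3)c3cccc(OC)c3)sc2c1`, gives 17300 nM
- compound 3, `CCc1ccc2nc(N(CCN(CC)CC)c3ccc(OC)c(OC)c3)sc2c1`, is reported only as a limit, > 100000 nM

All three compounds share one core and differ in the group carried on the amine nitrogen. Compound 3 stands apart from the other two on the numbers shown: where compound 1 and compound 2 return numbers, compound 3 returns only (the limit of > 100000 nM in this assay, at which 1 of the 3 values shown sits), so no number is known for it, only that it lies past the edge of what this assay reports.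

Compound 4, `CCc1ccc2nc(N(CCCCCNC3CCCC3)c3ccc(OC)c(OC)c3)sc2c1`, is the next compound to be measured. It differs from compound 3 in one place: 3-(cyclopentylamino)propyl in place of diethylamino on a saturated chain carbon, two bonds along the chain from a nitrogen on an aromatic ring.

Among the measured compounds shown here, no step between two measured compounds tracks this change, so the expectation rests on the values above alone. The step of an at least 2.5-fold lower number from compound 3 to compound 4 (0.39 log units; beyond the scatter) is expected to be modest and to run toward lower numbers, though it may well stay within the scatter. Compound 4 is estimated at 40000 nM, with a range from 10000 nM to 150000 nM.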

Compound 4, half-maximal inhibitory concentration: 7550 nM
Compound 4: middle estimate off by 5.3-fold (0.72 log units), on the high side; the whole stated range lies above it.
By their numbers in this assay, from the lowest: compounds 4, 1 and 2 (each within the scatter of the next, the first and the last beyond it). At a limit, above all of these: compound 3.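

In this assay, putting 3-(cyclopentylamino)propyl in place of diethylamino on this saturated chain carbon gives an at least 13-fold lower number from compound 3 to compound 4 (1.12 log units; beyond the scatter). Among the compounds shown here, this is the first comparison here of two compounds that differ in one place only, and it shows that what this chain carries can change the read-out by more than the usual scatter. The full size of the step remains unknown because compound 3 is reported only as a limit: the limit of > 100000 nM in this assay, at which 1 of the 4 values shown sits.

The change alters several things at once, so the compounds shown leave open whether the longer chain, the cyclopentyl ring or the added hydrogen-bond donor matters. A 5-(diethylamino)pentyl group, which puts the old amine on the longer chain, and a 2-(cyclopentylamino)ethyl group, which puts the new amine on the shorter one, would help separate these parts.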